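The compounds below may be only part of what the source reports. "The series", "measured", "known", "first", "only" and "open" are said of these compounds alone.

Four compounds share a five-membered ring that carries an aromatic group on its amide-type nitrogen, and three of them have been measured in a functional assay on HOS-TE85 cells (Homo sapiens) for inhibition, read by CCK-8 assay, with a stated time of 72 h, tested at 1 uM; on this read-out lower numbers stand for less inhibition and higher numbers for more inhibition at the one concentration tested (going by the name of the read-out). Compound 1 `COc1ccccc1N1C(=O)C(C)SC1c1cccc(C(=O)NCCCCc2ccccc2)c1` gives 95%. Compound 2 `COc1ccc(C)cc1N1C(=O)CSC1c1cccc(C(=O)NCCCCc2ccccc2)c1` gives 95%, level with compound 1 at the digits shown, and together these two stand highest of the three measured numbers. Compound 3 `COc1ccccc1N1C(=O)CSC1C(=O)NCCCCc1ccccc1` gives 0%, a result far below compound 2, well beyond the scatter of this assay.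

Compound 4 `COc1cc(F)ccc1N1C(=O)CSC1c1cccc(C(=O)NCCCCc2ccccc2)c1` has not been measured. It differs from compound 2 in one place: 4-fluoro-2-methoxyphenyl in place of 2-methoxy-5-methylphenyl on an amide-type nitrogen in a ring. Among the compounds with values here, the swap exchanges one small aromatic group for another of the same size on the amide-type nitrogen in a ring, and nothing among the measured compounds shows what such a swap does.

Because compound 2 gives 95%, a step no larger than the scatter is expected, the estimated change being a number 5 percentage points lower from compound 2 to compound 4 (within the scatter). Compound 4 is therefore expected to reach about 90%, within a range from 70% to 99%.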

Compound 4, a percentage reported as inhibition, at one concentration (the size of the read-out at that concentration, not a potency): 94%
Beside the measured number, compound 4's estimate is 4 percentage points below it; the range from low to high includes it.
By their numbers in this assay, from the lowest: compound 3; then compounds 4, 1 and 2 (each within the scatter of the next).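

Within the data shown here, putting 4-fluoro-2-methoxyphenyl in place of 2-methoxy-5-methylphenyl on the amide-type nitrogen in a ring gives the first step at this position in this assay, with a number 1 percentage points lower from compound 2 to compound 4 (within the scatter). At this one concentration, the read-out therefore does not tell the two aromatic groups apart, so this position accepts this particular exchange of a methyl group and a fluorine atom on the ring. Nothing available explains why the two compounds read alike.

On these data alone, it remains open whether this position would accept an aromatic ring carrying a carboxylic acid or an amine, or a ring with no methoxy group at all. A reading at a single concentration also leaves open whether compound 2 and compound 4 would separate at lower concentrations.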